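Amide substituent exchange on compound 2: expectation for compound 4

A few compounds are considered here, and "the series" means these few. Any claim that something is new, unique, unknown or untested is made for them only; others in the source may bear on it.

Measured so far:
compound 1 `CN(C)C(=O)/C=C1\CCc2c(F)cc(F)cc21` — 100%
compound 2 `O=C(/C=C1\CCc2ccc(F)cc21)NCC1CC1` — 50%
compound 3 `NC(=O)/C=C1\CCc2c(F)cc(F)cc21` — 100%

All three numbers come from a functional assay on the whole organism with Mus musculus as the target, at a dose of 100 mg/kg by the intraperitoneal route; on this read-out lower numbers stand for less inhibition and higher numbers for more inhibition at the one dose given (going by the name of the read-out). Compound 2 stands lowest of the three; compound 1 and compound 3 each lie higher by a margin beyond the scatter. Compound 4 `O=C(/C=C1\CCc2ccc(F)cc21)N1CCC1` differs from compound 2 by azetidin-1-yl in place of (cyclopropylmethyl)amino on a carbonyl carbon.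

Within the data shown here, the only measured step at the carbonyl carbon is no change at the digits printed from compound 1 to compound 3 (within the scatter). Among the measured compounds shown here, it exchanges one amide substituent for another on a core that differs from that of compound 2, and both partners already sit at the top of the read-out, so it shows only that such an exchange need not cost inhibition; it cannot show a gain. Nothing measured tests the loss of the hydrogen-bond donor on the core shared by compound 2 and compound 4.

The estimated step is therefore a number 15 percentage points higher from compound 2 to compound 4 (beyond the scatter), a small rise with wide uncertainty. Compound 4 is estimated at 65%, with a range from 30% to 100%.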

Compound 4, a percentage reported as inhibition, in the whole organism at one dose (the size of the read-out at that dose, not a potency): 33%
The estimate for compound 4 lay 32 percentage points above the measured number, within the range that was stated.
By their numbers in this assay, from the lowest: compound 4; then compound 2; then compounds 1 and 3 (each within the scatter of the next).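

In this assay the exchange of (cyclopropylmethyl)amino for azetidin-1-yl on the carbonyl carbon gives a number 17 percentage points lower from compound 2 to compound 4 (beyond the scatter) and so shows that, on the core shared by these two compounds, the read-out responds to the amide substituent. The earlier exchange at this carbonyl carbon gave no change at the digits printed from compound 1 to compound 3 (within the scatter) on a different core, with both partners at the top of the read-out, so it could not reveal a loss of this kind. No measurement at hand bears on the origin of the lower number.

Open, on these data alone, is how pyrrolidin-1-yl, or a longer chain such as butylamino, would read on the carbonyl carbon of the shared core. The compounds shown also leave open whether the amide hydrogen or the ring carries the step, since both change together in this one exchange.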